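Swapping one aromatic ring for another on compound 1

The compounds below may be only part of what the source reports. "The series", "measured", "known", "first", "only" and "open" are said of these compounds alone.

Compound 1 `O=C(O)c1ccccc1-c1ccc(CCc2ncc(Cc3cccc(Cl)c3)[nH]2)cc1` belongs to a small set of three compounds tested in an in vitro functional assay on cells for agonist activity at Bombesin receptor subtype-3 (Homo sapiens), read by luminescence and calcium flux; on this read-out higher numbers stand for an effect only at larger amounts of compound and lower numbers for an effect already at smaller amounts. There compound 1 gives 825 nM, which places it second highest among the three numbers. Compound 2 `O=C(O)c1ccccc1-c1ccc(CCc2ncc(CC3CCC3)[nH]2)cc1` gives 588 nM, and the step of a 1.4-fold lower number from compound 1 to compound 2 (0.15 log units; within the scatter) is modest. Compound 3 `CC(C)(C)c1cnc(CCc2ccc(-c3ccccc3C(=O)O)cc2)[nH]1` gives 4330 nM, and the steps of a 5.2-fold higher number from compound 1 to compound 3 (0.72 log units; beyond the scatter) and a 7.4-fold higher number from compound 2 to compound 3 (0.87 log units; beyond the scatter) are the only ones that clearly exceed the scatter.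

Compound 4 `COc1ccc(Cc2cnc(CCc3ccc(-c4ccccc4C(=O)O)cc3)[nH]2)cc1` is not yet measured. It differs from compound 1 in one place: 4-methoxyphenyl in place of 3-chlorophenyl on a saturated chain carbon bound to an aromatic carbon. For the measured compounds named here, of the measured steps, only the one from compound 1 to compound 2 touches the same position, and it replaced the same group with cyclobutyl without a change beyond the scatter. The two larger steps concern a different change, the loss of the connecting chain carbon in compound 3, so they do not speak to compound 4. Going by the values given here, no measured step compares two aromatic rings at this position. The expectation is therefore a step of a 1.1-fold higher number from compound 1 to compound 4 (0.04 log units; within the scatter) that stays within the scatter. Compound 4 is estimated to give 900 nM, with a likely range from 400 nM to 2500 nM.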

Compound 4, half-maximal effective concentration: 5360 nM
Beside the measured number, compound 4's estimate is 6.0-fold (0.77 log units) below it, and the stated range ends below it.
By their numbers in this assay, from the lowest: compounds 2 and 1 (each within the scatter of the next); then compounds 3 and 4 (each within the scatter of the next).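

In this assay, for the compounds shown here, the earlier compounds showed only that cyclobutyl can replace 3-chlorophenyl on this saturated chain carbon without a clear change. Exchanging one aromatic ring for another now gives a 6.5-fold higher number from compound 1 to compound 4 (0.81 log units; beyond the scatter) and so shows that an aromatic ring at this place does not by itself settle the number, since the groups on that ring matter as well. Measured against the cyclobutyl group, 4-methoxyphenyl gives a 9.1-fold higher number from compound 2 to compound 4 (0.96 log units; beyond the scatter) while replacing tert-butyl with 4-methoxybenzyl gives only a 1.2-fold higher number from compound 3 to compound 4 (0.09 log units; within the scatter) and leaves those two compounds indistinguishable on this read-out. Nothing shown here explains why the number moves with this change.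

This change alters both the substituent and its place on the ring at once, and the compounds shown cannot separate the two. A 4-chlorophenyl or a 3-methoxyphenyl group at this position would pull those two apart, and an unsubstituted phenyl ring would show whether either substituent is needed at all.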